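The source may report more compounds than this note shows. Statements on the series, on what has been measured and on what is new or still open speak of the compounds shown alone.

Of the compounds shown here, three have been tested so far in an ADME assay on cells (Homo sapiens) for cytotoxicity, read by resazurin assay, with a stated time of 5 days; a lower number here means that less compound is tolerated, a higher number that more compound is tolerated. Compound 1 `COc1ccc(-c2nc(C3(S(=O)(=O)c4cccc(Cl)c4)CC3)nc3ccsc23)cn1` gives > 50000 nM, which is a limit of the assay and not a number. Compound 2 `c1ccc(-c2cc(CNc3nncc(-c4cccc5ccccc45)n3)n[nH]2)cc1` gives > 10000 nM, also a limit. Compound 3 `COc1ccc(-c2nc(CCc3cccc(Cl)c3)nc3ccsc23)cn1` gives > 50000 nM, again a limit. Compound 3 therefore stands at the limit of > 50000 nM in this assay, at which 2 of the 3 values shown sit, and no exact number is available for it.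

Compound 4 `COc1ccc(-c2nc(CNc3cccc(Cl)c3)nc3ccsc23)cn1` changes compound 3 in one place: (3-chlorophenyl)amino in place of 3-chlorobenzyl on a saturated chain carbon bound to an aromatic carbon. Here (3-chlorophenyl)amino stands in place of 3-chlorobenzyl on a saturated chain carbon bound to an aromatic carbon.

Among the measured compounds shown here, no two measured compounds differ in just one place, so no measured step can serve as a guide. The expectation is therefore no step beyond the usual scatter, resting on compound 3 with its limit of > 50000 nM. The estimated step of an at least 1.1-fold lower number from compound 3 to compound 4 (0.04 log units; that floor lies within the scatter) stays within that scatter, and any real shift is expected toward a lower number. For compound 4 the estimated value is 45000 nM, with an expected range from 15000 nM to 50000 nM.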

Compound 4, half-maximal cytotoxic concentration: > 50000 nM
Compound 4 was reported as a limit; the forecaster's own chance of this, stated with the estimate: 70%; middle value at least 1.1-fold (0.04 log units) away from the limit.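

Among the compounds shown here, compound 3 and compound 4 are both reported only as limits in this assay, so no step between them can be read. Left open is whether (3-chlorophenyl)amino in place of 3-chlorobenzyl changes the read-out at all, and at what concentration either compound turns cytotoxic.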